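The source may hold more compounds than are shown below. What is called first, only, known or untested is meant among the compounds shown, and "the series" means these compounds.

Working notes on the series. Compound 1 `CCOC(=O)c1c(-c2ccc(Cl)cc2)cc(-c2ccccc2)nc1N1CCCCC1` and compound 2 `CCOC(=O)c1c(-c2ccc(Cl)cc2)cc(-c2ccccc2)nc1N1CCN(C)CC1` share one core and differ only at the amine on the aromatic carbon. In a functional assay on the whole organism (strain Wister albino) for inhibition, with Rattus norvegicus as the target, read by paw edema, with stated times of 1 h and 24 h, at a dose of 50 mg/kg by the intraperitoneal route (a higher number here means more inhibition at the dose given (going by the name of the read-out), a lower number less inhibition), compound 1 gives 36.4%, and compound 2 gives 53.2%. Among the measured compounds shown here, the one step measured, a number 16.8 percentage points higher from compound 1 to compound 2 (beyond the scatter), is the only guide available; on these two numbers compound 2 stands highest, with compound 1 the nearer and lower of the pair. Compound 3 `CCOC(=O)c1c(-c2ccc(Cl)cc2)cc(-c2ccccc2)nc1Nc1ccccc1` is not yet measured; it differs from compound 2 by anilino in place of 4-methylpiperazin-1-yl on an aromatic carbon. For the measured compounds named here, no measured step covers an anilino group at this position, so the change from compound 2 to compound 3 has no direct precedent, and the step from compound 1 to compound 2 bears on it only in showing that the amine at this carbon moves the read-out by a modest amount. A shift downward toward the region of compound 1, or none beyond the scatter, is expected, with a number 11.2 percentage points lower from compound 2 to compound 3 (beyond the scatter) as the estimated step. For compound 3 the expected value is 42%, estimated within 25% to 60%.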

Compound 3, a percentage reported as inhibition, in the whole organism at one dose (the size of the read-out at that dose, not a potency): 46.5%
Estimate against measurement, compound 3: 4.5 percentage points below; the range from low to high includes it.
By their numbers in this assay, from the lowest: compound 1; then compounds 3 and 2 (each within the scatter of the next).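

Replacing 4-methylpiperazin-1-yl with anilino, an aromatic ring of carbon only that carries a hydrogen-bond donor, gives a number 6.7 percentage points lower from compound 2 to compound 3 (within the scatter) in this assay, so this carbon accepts two very different rings without a change beyond the scatter. The non-aromatic ring with two hetero atoms is therefore not required for the read-out seen with compound 2. Anilino also gives a number 10.1 percentage points higher from compound 1 to compound 3 (beyond the scatter), which leaves piperidin-1-yl as the one group of the three that stands apart, lying beyond the scatter below both others.

The compounds shown leave open how morpholin-4-yl, piperazin-1-yl without its methyl, or a chloro-substituted anilino would read at this carbon. They also leave open whether the pattern holds with a carboxylic acid in place of the ethoxycarbonyl group. No supporting data bear on the difference among these three amines.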